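Ethyl in place of allyloxy on a carbonyl carbon

The source may hold more compounds than are shown below. What is called first, only, known or untested is meant among the compounds shown, and "the series" means these compounds.

In a functional assay on MCF7 cells (Homo sapiens) for inhibition, read by MTT assay, with a stated time of 96 h (on this read-out lower numbers stand for stronger inhibition of growth and higher numbers for weaker inhibition of growth), compound 2 `C=CCOC(=O)SCCCCCCNC(=O)c1cc(-c2ccncc2)n[nH]1` gives 12600 nM, which lies within the scatter of compound 1 `O=C(OCc1ccccc1)SCCCCCCNC(=O)c1cc(-c2ccncc2)n[nH]1` at 8370 nM. Compound 3 `CCC(=O)SCCCCCCNC(=O)c1cc(-c2ccncc2)n[nH]1` carries ethyl in place of allyloxy on a carbonyl carbon. Going by the values given here, the only measured step, a 1.5-fold higher number from compound 1 to compound 2 (0.18 log units; within the scatter), is small, but it exchanged phenyl for vinyl and left the oxygen in place, so it bears on this change only weakly. No shift beyond the scatter is therefore expected in this assay, and the expected step is a 1.6-fold lower number from compound 2 to compound 3 (0.20 log units; within the scatter). For compound 3 the estimate is 8000 nM, with an expected range of 2500 nM to 25000 nM.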

Compound 3, concentration for 50% growth inhibition: > 50000 nM
Compound 3 gave a limit, no number (the forecaster's own chance of this, stated with the estimate: 5%); middle value at least 6.2-fold (0.79 log units) from the limit.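

In this assay compound 3 gives only a limit, not a number: the limit of > 50000 nM in this assay, at which 1 of the 3 values shown sits. Even so, ethyl in place of allyloxy gives an at least 3.9-fold higher number from compound 2 to compound 3 (0.59 log units; beyond the scatter), and ethyl in place of benzyloxy gives an at least 5.9-fold higher number from compound 1 to compound 3 (0.77 log units; beyond the scatter). Compound 1 and compound 2, both with an oxygen on this carbonyl carbon, lie within the scatter of each other, so only compound 3 shows that the read-out responds to a change at this position.

Compound 3 loses the oxygen and shortens the group together, and the compounds shown do not separate the two. From the compounds shown here alone, whether an amine on this carbonyl carbon or a longer chain in place of ethyl would behave like allyloxy remains open.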